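This account rests on a few compounds, and the source may have more. Where it says the series, first, only, none or still open, it means among the compounds named here.

Compound 1 `COc1cc(CCc2ccc(F)cc2)cc(OC)c1O`: 4150 nM
Compound 2 `COc1cc(CCc2ccccn2)cc(OC)c1O`: > 25000 nM

Among the measured compounds shown here, in a functional assay on A549 cells (Homo sapiens) for antiproliferative activity, read by MTT assay, with a stated time of 72 h (a lower number here means a stronger inhibitor, a higher number a weaker inhibitor), compound 1 gives 4150 nM, the only plain number among the two values. The value of compound 2 is a limit of the assay, > 25000 nM, and it sits at the limit of > 25000 nM in this assay, at which 1 of the 2 values shown sits. Compound 3 `COc1cc(CCc2ccc(Cl)cc2)cc(OC)c1O` has not yet been measured. It differs from compound 1 by chloro in place of fluoro on an aromatic carbon. For the measured compounds named here, no measured pair shows this change, so in this assay the step is expected to stay within the scatter, if anything toward a slightly lower number. Compound 3 is therefore expected to give 3000 nM, with a range from 1000 nM to 10000 nM. The expected step is a 1.4-fold lower number from compound 1 to compound 3 (0.14 log units; within the scatter).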

Compound 3, half-maximal inhibitory concentration: 22900 nM
For compound 3 the middle estimate is 7.6-fold (0.88 log units) below the measured one, outside the stated range (above it).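

In this assay, the halogen on this aromatic carbon, para to a large group, is not interchangeable: chloro in place of fluoro gives a 5.5-fold higher number from compound 1 to compound 3 (0.74 log units; beyond the scatter). A swap of one heavy atom for another at this position is therefore enough to weaken the compound clearly. Compound 3 now reads close to the value for compound 2, which is a limit and not a number: the limit of > 25000 nM in this assay, at which 1 of the 3 values shown sits.

Still open, on these data alone, is whether any other group here would match fluoro or improve on it. Bromo, methyl or an amine on this carbon would show whether fluoro is a special case.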